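Compound 2 to compound 3: an aryl swap on the shared core

The source may report more compounds than this note shows. Statements on the series, on what has been measured and on what is new or still open speak of the compounds shown alone.

Measured so far in a functional assay on SGC-7901 cells (Homo sapiens) for antiproliferative activity, read by MTT assay, with a stated time of 72 h; a higher number here means a weaker inhibitor, a lower number a stronger inhibitor
- compound 1 `COc1cc(-n2cnc3ccc(-c4ccc(Cl)cc4)cc32)cc(OC)c1OC` gives 1270 nM
- compound 2 `COc1cc(-n2cnc3ccc(-c4ccc(F)cc4)cc32)cc(OC)c1OC` gives 3500 nM

Compound 2 at 3500 nM holds the higher of the two numbers. Compound 3 `COc1cccc(-c2ccc3ncn(-c4cc(OC)c(OC)c(OC)c4)c3c2)c1` differs from it thus: 3-methoxyphenyl in place of 4-fluorophenyl on an aromatic carbon and so carries 3-methoxyphenyl in place of 4-fluorophenyl on an aromatic carbon. Among the compounds with values here, the only measured step is a 2.8-fold higher number from compound 1 to compound 2 (0.44 log units; beyond the scatter) and it is modest. It swaps fluoro for chloro, a different change, so it bears only loosely here. A small step toward a lower number in this assay is expected, not clearly beyond the scatter. The estimate thus means a 1.8-fold lower number from compound 2 to compound 3 (0.24 log units; within the scatter) and no more. Compound 3 is expected in this assay at 2000 nM with 600 nM to 7000 nM as its likely range.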

Compound 3, half-maximal inhibitory concentration: 3310 nM
The estimate for compound 3 lay 1.7-fold (0.22 log units) below the measured number; the range from low to high includes it.
By their numbers in this assay, from the lowest: compound 1; then compounds 3 and 2 (each within the scatter of the next).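

In this assay, 3-methoxyphenyl and 4-fluorophenyl are not told apart at this position, with a 1.1-fold lower number from compound 2 to compound 3 (0.02 log units; within the scatter) as the step. The gain held by 4-chlorophenyl is not matched by 3-methoxyphenyl either, with a 2.6-fold higher number from compound 1 to compound 3 (0.42 log units; beyond the scatter) as the step, so among the three groups only 4-chlorophenyl stands apart. No data at hand account for these steps.

Open, going by these compounds, is whether 4-methoxyphenyl would sit with 3-methoxyphenyl or with 4-chlorophenyl. Also open, on these data alone, is whether 4-bromophenyl, or an aryl ring carrying an amine, would give a lower number than compound 1.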